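Methyl on the Phenyl Ring: Cytotoxicity Expectations

This account rests on a few compounds, and the source may have more. Where it says the series, first, only, none or still open, it means among the compounds named here.

Of the compounds shown here, three sharing one core have been tested in an ADME assay on PANC-1 cells (Homo sapiens) for cytotoxicity, read by MTT assay; on this read-out lower numbers stand for higher toxicity in this test and higher numbers for lower toxicity in this test. Compound 1 `Cc1nc(-c2cccnc2)sc1-c1nnc(-c2ccc(Br)cc2)o1` carries a 4-bromophenyl group. In this assay compound 1 reaches only the limit of the test, > 100 ug/mL. Compound 2 `COc1ccccc1-c1nnc(-c2sc(-c3cccnc3)nc2C)o1` carries a 2-methoxyphenyl group instead. In this assay compound 2 likewise sits at the limit, > 100 ug/mL. Compound 3 `Cc1nc(-c2cccnc2)sc1-c1nnc(-c2ccccc2)o1` carries the plain phenyl group. In this assay compound 3 also ends at the limit, > 100 ug/mL. Because all three rest at the limit of > 100 ug/mL in this assay, at which 3 of the 3 values shown sit, none of the steps among them can be sized: a step that the two limits leave unreadable from compound 1 to compound 2, a step that the two limits leave unreadable from compound 1 to compound 3 and a step that the two limits leave unreadable from compound 2 to compound 3 are all unreadable. Compound 3 thus stands where the other two stand, at the limit.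

Compound 4 `Cc1cccc(-c2nnc(-c3sc(-c4cccnc4)nc3C)o2)c1` differs from compound 3 by one change: methyl in place of hydrogen on an aromatic carbon, so that phenyl becomes 3-methylphenyl. Among the compounds with values here, no measured step bears on this change with a readable size; the three unreadable steps show only that exchanging bromo, methoxy or hydrogen on that ring left every compound at the limit. The step expected here is a step that the limit leaves unreadable from compound 3 to compound 4, nothing beyond the scatter. In this assay compound 4 is expected to give about 150 ug/mL, between 70 ug/mL and 400 ug/mL, most probably again reported only as a limit.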

Compound 4, half-maximal cytotoxic concentration: > 100 ug/mL
Compound 4: a limit, no number; the forecaster's own chance of this, stated with the estimate: 85%; the middle value does not contradict the limit.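

Within the data shown here, compound 4 also gives only a limit, so no step from compound 1, compound 2 or compound 3 to compound 4 can be read, because all four compounds rest at the same limit: the limit of > 100 ug/mL in this assay, at which 4 of the 4 values shown sit.

The compounds shown leave open whether bromo, methoxy or methyl on the phenyl ring changes the result in this assay at all.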